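A few compounds are considered here, and "the series" means these few. Any claim that something is new, unique, unknown or untested is made for them only; others in the source may bear on it.

Measured so far in an assay on HEK293 cells for agonist activity at Toll-like receptor 8 (Homo sapiens), read by a luciferase reporter, with a stated time of 6 h; on this read-out lower numbers stand for an effect already at smaller amounts and higher numbers for an effect only at larger amounts of compound:
compound 1 `CCCCNc1nc(N)nc2c1CCN(C)C2` — 0.2 uM
compound 2 `CCCCNc1nc(N)nc2c1CN(C(=O)c1ccccc1)CC2` — 1.4 uM
compound 3 `CCCCNc1nc(N)nc2c1CCN(C(=O)c1ccccc1)C2` — 0.8 uM

Compound 2 gives the highest number of the three. Against compound 3 the gap is within the scatter; against compound 1 it is beyond it. For the measured compounds named here, the one single-place step in the set, a 4.0-fold higher number from compound 1 to compound 3 (0.60 log units; beyond the scatter), concerns the exchange of benzoyl in place of methyl on an amine nitrogen in a ring, and in this assay it moves the number upward modestly. Compound 4 `CCCCNc1nc(N)nc2c1CN(C(=O)c1cscn1)CC2` differs from compound 2 by 1,3-thiazol-4-yl in place of phenyl on a carbonyl carbon. Going by the values given here, no measured pair exchanges one aromatic group for another on the carbonyl carbon, so the set holds nothing that bears directly on this change; the step from compound 1 to compound 3 shows only that the amide substituent matters at all. Among the compounds with values here, with no relevant precedent, the expected step of no change at the digits printed from compound 2 to compound 4 (within the scatter) is none beyond the scatter, with a wide range. Compound 4 is therefore estimated at 1.4 uM in this assay, between 0.5 uM and 4 uM.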

Compound 4, minimum effective concentration: 0.5 uM
The estimate for compound 4 lay 2.8-fold (0.45 log units) above the measured number; measured number inside the range.
By their numbers in this assay, from the lowest: compound 1; then compounds 4, 3 and 2 (each within the scatter of the next, the first and the last beyond it).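

In this assay there is a 2.8-fold lower number from compound 2 to compound 4 (0.45 log units; beyond the scatter), so the group on this carbonyl carbon responds to an exchange of one aromatic ring for another, which the earlier methyl-to-benzoyl step could not show. The entering 1,3-thiazol-4-yl is a five-membered ring with hetero atoms and hydrogen-bond acceptors that phenyl lacks, but this single pair cannot separate ring size from hetero atoms. No measurement here bears on why the number moves.

Going by these compounds, it remains open whether a pyridyl or furyl group on the same carbonyl carbon would give a similar number, or whether an open-chain acetyl group would lose the effect of an aromatic ring. Also open, on these data alone, is whether the same exchange would carry over to the core of compound 3.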